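Bromo to methoxy swap: expected antiproliferative step

The source may report more compounds than this note shows. Statements on the series, on what has been measured and on what is new or still open speak of the compounds shown alone.

Measured so far in a functional assay on HCT-116 cells (Homo sapiens) for antiproliferative activity, read by CCK-8 assay, with a stated time of 72 h; on this read-out higher numbers stand for weaker inhibition and lower numbers for stronger inhibition:
Compound 1 `Nc1ccccc1NC(=O)c1ccc(COc2ccc(Br)cc2)cc1` gives > 32000 nM, which is a limit of the assay and not a number.
Compound 2 `Nc1ccccc1NC(=O)c1ccc(COc2ccc(F)cc2)cc1` gives 3860 nM.
Compound 3 `CC(C)c1ccc(OCc2ccc(C(=O)Nc3ccccc3N)cc2)cc1` gives 4570 nM.

Compound 1 is the only one of the three without a number, sitting at the limit of > 32000 nM in this assay, at which 1 of the 3 values shown sits. Compound 4 `COc1ccc(OCc2ccc(C(=O)Nc3ccccc3N)cc2)cc1` differs from it by methoxy in place of bromo on an aromatic carbon. Two measured steps replace the same bromo: an at least 8.2-fold lower number from compound 1 to compound 2 (0.91 log units; beyond the scatter) and an at least 7.0-fold lower number from compound 1 to compound 3 (0.84 log units; beyond the scatter). Both move the number down off the limit, and compound 2 against compound 3 shows a 1.2-fold higher number from compound 2 to compound 3 (0.07 log units; within the scatter), so fluoro and isopropyl land close together. Methoxy is expected to behave alike, giving an estimated step of an at least 7.1-fold lower number from compound 1 to compound 4 (0.85 log units; beyond the scatter) in this assay. Compound 4 is therefore estimated at 4500 nM, with a range from 1500 nM to 15000 nM.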

Compound 4, half-maximal inhibitory concentration: 2020 nM
Compound 4: the middle estimate sits 2.2-fold (0.35 log units) above what was measured; low and high end bracket the measured number.
By their numbers in this assay, from the lowest: compounds 4, 2 and 3 (each within the scatter of the next, the first and the last beyond it). At a limit, above all of these: compound 1.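

Methoxy in place of bromo on the aromatic carbon gives an at least 15-fold lower number from compound 1 to compound 4 (1.19 log units; beyond the scatter) in this assay. That step starts from a limit and not a number for compound 1: the limit of > 32000 nM in this assay, at which 1 of the 4 values shown sits. The other replacements now separate at this position: a 2.3-fold lower number from compound 3 to compound 4 (0.35 log units; beyond the scatter), whereas a 1.9-fold lower number from compound 2 to compound 4 (0.28 log units; within the scatter), so methoxy stands apart from isopropyl but not from fluoro.

As far as these compounds go, whether an amine, a hydroxyl or a longer alkoxy chain here would stay close to compound 4 remains open. Why only bromo, among these four groups, sits at the limit also remains open.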